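Benzyloxy variants on a trimethoxyphenyl chromone core

The compounds below may be only part of what the source reports. "The series", "measured", "known", "first", "only" and "open" are said of these compounds alone.

Measured so far in a functional assay on HCT-116 cells (Homo sapiens) for antiproliferative activity, read by MTT assay, with a stated time of 24 h; a lower number here means a stronger inhibitor, a higher number a weaker inhibitor:
- compound 1 `C=CCOc1ccc2c(=O)c(-c3cc(OC)c(OC)cc3OC)coc2c1`: 6600 nM
- compound 2 `COc1cc(OC)c(-c2coc3cc(OCc4ccccc4)ccc3c2=O)cc1OC`: 2280 nM
- compound 3 `COc1cc(OC)c(-c2coc3cc(OCc4ccccc4C(F)(F)F)ccc3c2=O)cc1OC`: 4760 nM

Compound 1 carries the highest number of the three. Its nearest neighbour is compound 3, where the gap a 1.4-fold lower number from compound 1 to compound 3 (0.14 log units; within the scatter) stays within the scatter; the furthest is compound 2, reached by a 2.9-fold lower number from compound 1 to compound 2 (0.46 log units; beyond the scatter).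

The next compound, compound 4 `COc1cc(OC)c(-c2coc3cc(OCc4ccccc4Cl)ccc3c2=O)cc1OC`, differs from compound 1 by 2-chlorophenyl in place of vinyl on a saturated chain carbon bound to an oxygen on an aromatic ring. Among the compounds with values here, two measured steps bear on this. Replacing the vinyl by a bare phenyl, a 2.9-fold lower number from compound 1 to compound 2 (0.46 log units; beyond the scatter), is a modest gain. Replacing it by the 2-(trifluoromethyl)phenyl, a 1.4-fold lower number from compound 1 to compound 3 (0.14 log units; within the scatter), brings almost nothing, and the trifluoromethyl itself, a 2.1-fold higher number from compound 2 to compound 3 (0.32 log units; beyond the scatter), costs a modest amount against the bare phenyl. A 2-chlorophenyl sits between these two cases in what enters, so the number for compound 4 is expected to fall between those of compound 2 and compound 3, most likely closer to the middle.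

The step from compound 1 is therefore expected to be a 1.9-fold lower number from compound 1 to compound 4 (0.29 log units; within the scatter), a modest gain and smaller than that seen for compound 2. Compound 4 is estimated at 3400 nM, with a plausible range from 1800 nM to 6500 nM.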

Compound 4, half-maximal inhibitory concentration: 2450 nM
The estimate for compound 4 lay 1.4-fold (0.14 log units) above the measured number; measured number inside the range.
By their numbers in this assay, from the lowest: compounds 2, 4, 3 and 1 (each within the scatter of the next, the first and the last beyond it).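

In this assay, 2-chlorophenyl in place of vinyl gives a 2.7-fold lower number from compound 1 to compound 4 (0.43 log units; beyond the scatter) and thus joins the bare phenyl of compound 2 as a replacement on this saturated chain carbon whose step from compound 1 lies beyond the scatter, which the step to the 2-(trifluoromethyl)phenyl of compound 3 did not. Chloro in place of hydrogen on the aromatic carbon gives a 1.1-fold higher number from compound 2 to compound 4 (0.03 log units; within the scatter) and cannot be told apart from hydrogen here, whereas trifluoromethyl in the same place gave a 2.1-fold higher number from compound 2 to compound 3 (0.32 log units; beyond the scatter) and did leave the scatter. Chloro in place of trifluoromethyl gives a 1.9-fold lower number from compound 3 to compound 4 (0.29 log units; within the scatter) and also stays within the scatter, so compound 4 separates from neither compound 2 nor compound 3, and the one readable gap among these three is the one between compound 2 and compound 3.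

The compounds shown leave open how an amine or a carboxylic acid on the same aromatic carbon would read, and whether a longer chain in place of the vinyl would match the aromatic replacements. No measurement to hand accounts for any of these steps.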